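Moving a halogen on the anilino ring of compound 3

The compounds below may be only part of what the source reports. "The series", "measured", "known", "first", "only" and "open" are said of these compounds alone.

Measured compounds:
compound 1 `C=CC(=O)Nc1cccc(NC(=O)CSc2nc(Nc3ccccc3)c3ccccc3n2)c1` — 7310 nM
compound 2 `O=C(CSc1nc(Nc2ccccc2)c2ccccc2n1)Nc1ccc(C(F)(F)F)cc1` — 8670 nM
compound 3 `C=CC(=O)Nc1cccc(NC(=O)CSc2nc(Nc3ccccc3Br)c3ccccc3n2)c1` — 12800 nM

In a functional assay on MGC-803 cells (Homo sapiens) for inhibition, read by MTT assay, with a stated time of 72 h (on this read-out higher numbers stand for weaker inhibition and lower numbers for stronger inhibition), compound 3 gives 12800 nM. This is the highest of the three numbers, yet its distance to each of the others stays within the scatter: compound 2 gives 8670 nM and compound 1 gives 7310 nM, so no order among the three can be claimed.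

Compound 4 `C=CC(=O)Nc1cccc(NC(=O)CSc2nc(Nc3cccc(Cl)c3)c3ccccc3n2)c1` has not been measured. It differs from compound 3 by one change: 3-chlorophenyl in place of 2-bromophenyl on a nitrogen on an aromatic ring. Among the measured compounds shown here, the only measured step that touches this nitrogen is a 1.8-fold higher number from compound 1 to compound 3 (0.24 log units; within the scatter), which stayed within the scatter; the step of a 1.2-fold higher number from compound 1 to compound 2 (0.07 log units; within the scatter) lies at the amide nitrogen and does not bear on it. Both changes left the read-out essentially where it was. For the measured compounds named here, compound 4 keeps a halogen on the anilino ring but as chloro at the 3-position instead of bromo at the 2-position, and no step measured here tests that difference directly.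

Compound 4 is therefore expected to give about 9500 nM in this assay, a step of a 1.3-fold lower number from compound 3 to compound 4 (0.13 log units; within the scatter) that does not exceed the scatter, with the estimate spanning 4000 nM to 22000 nM.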

Compound 4, half-maximal inhibitory concentration: 7830 nM
Beside the measured number, compound 4's estimate is 1.2-fold (0.08 log units) above it, within the range that was stated.
By their numbers in this assay, from the lowest: compounds 1, 4, 2 and 3 (each within the scatter of the next).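

In this assay, the change from 2-bromophenyl to 3-chlorophenyl on this nitrogen gives a 1.6-fold lower number from compound 3 to compound 4 (0.21 log units; within the scatter), and 3-chlorophenyl set against the same ring without a halogen gives a 1.1-fold higher number from compound 1 to compound 4 (0.03 log units; within the scatter). This position therefore tolerates a halogen of either kind at either of these two ring places with no change that can be told from the scatter, although compounds 3 and 4 differ in both the halogen and its place, so this step cannot separate the two. Nothing shown here offers an explanation for these numbers.

The compounds shown leave open whether 3-bromophenyl or 2-chlorophenyl would behave the same way. They also leave open whether an amine or a carboxylic acid on this ring would move the number beyond the scatter.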